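The source may hold more compounds than are shown below. What is called first, only, known or untested is meant among the compounds shown, and "the series" means these compounds.

The study centres on compound 1, `CC(C)Cc1ccc2c(NCCCNCc3ccco3)ccnc2c1`, which in a physicochemical assay for acid dissociation, gives 9.47. A second measured compound, compound 2, `COc1ccc(F)cc1CNCCCNc1ccnc2cc(-c3ccc(F)cc3)ccc12`, gives 9.47 in this assay. The two compounds share the same chain and core but are built up differently around it; compound 1 stands level with compound 2 at the digits shown, and the two values lie within the scatter of each other.

The step followed here leads from compound 1 to compound 3, `Clc1ccc(Oc2ccc3c(NCCCNCc4ccco4)ccnc3c2)cc1`, which has not yet been measured in this assay. The change is 4-chlorophenoxy in place of isobutyl on an aromatic carbon. The replacement sits on an aromatic carbon of the core, while the chain that carries the amine is kept intact.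

Going by the values given here, no step between measured compounds is available to judge this change. Given that compound 1 and compound 2 return the same value despite their different substitution, the step from compound 1 to compound 3 is expected to be a number 0.07 log units lower from compound 1 to compound 3 (within the scatter), no change beyond the scatter. Compound 3 is therefore estimated at 9.4, with a range from 9 to 9.8.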

Compound 3, acid dissociation constant: 9.28
For compound 3 the middle estimate is 0.12 log units above the measured one; the measured number falls inside the stated range.
By their numbers in this assay, from the lowest: compounds 3, 1 and 2 (each within the scatter of the next).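

In this assay, 4-chlorophenoxy in place of isobutyl on an aromatic carbon of the shared core gives a number 0.19 log units lower from compound 1 to compound 3 (within the scatter), so this single change leaves the read-out unmoved beyond the scatter. Compound 1 and compound 2 differed in more than one place and could not speak for this position alone, whereas this step isolates it: the entering group brings a six-membered aromatic ring of carbon only and a hydrogen-bond acceptor, neither of which isobutyl has, and the read-out in this assay still holds within the scatter. Nothing measured here accounts for that result, and no cause can be assigned to it.

What the compounds shown leave open is whether an amine or a carboxylic acid on the same aromatic carbon, in place of isobutyl, would also stay within the scatter of compound 1 in this assay. They also leave open whether a longer chain carrying the amine would keep the read-out there, since that chain is the same in compound 1 and compound 3.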